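The compounds below may be only part of what the source reports. "The series", "measured", "known", "first", "only" and "open" are said of these compounds alone.

Measured so far in a functional assay on RXF 393 cells (Homo sapiens) for inhibition, read by sulforhodamine B assay, with a stated time of 48 h; a higher number here means a weaker inhibitor of growth, a lower number a stronger inhibitor of growth:
compound 1 `COc1cc(-c2nn(-c3cccc(NC(=O)c4cccc(C(F)(F)F)c4)c3)cc2-c2ccncc2)ccc1Cl`: 3150 nM
compound 2 `COc1cc(-c2nn(-c3cccc(NC(=O)Nc4cccc(C(F)(F)F)c4)c3)cc2-c2ccncc2)ccc1Cl`: 1940 nM

Compound 2 gives the lowest of the two numbers, with compound 1 as its nearest neighbour; the two lie within the scatter of each other, so no order is read between them. For the measured compounds named here, the only measured step, a 1.6-fold lower number from compound 1 to compound 2 (0.21 log units; within the scatter), is within the scatter.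

Compound 3 `COc1cc(-c2nn(-c3cccc(NC(=O)c4ccc(Cl)c(C(F)(F)F)c4)c3)cc2-c2ccncc2)ccc1Cl` is not yet measured in this assay. It differs from compound 2 by 4-chloro-3-(trifluoromethyl)phenyl in place of (3-(trifluoromethyl)phenyl)amino on a carbonyl carbon. This largely reverses the change from compound 1 to compound 2, while the entering 4-chloro-3-(trifluoromethyl)phenyl differs from the 3-(trifluoromethyl)phenyl of compound 1 by a chlorine. The measured step that bears on the reversal, a 1.6-fold lower number from compound 1 to compound 2 (0.21 log units; within the scatter), was within the scatter; nothing measured bears on the chlorine. A step of a 1.3-fold higher number from compound 2 to compound 3 (0.11 log units; within the scatter) is therefore expected, not beyond the scatter. The estimate for compound 3 is 2500 nM, with a range from 1000 nM to 7000 nM.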

Compound 3, concentration for total growth inhibition: 18700 nM
Beside the measured number, compound 3's estimate is 7.5-fold (0.87 log units) below it; the measured number lies above the stated range.
By their numbers in this assay, from the lowest: compounds 2 and 1 (each within the scatter of the next); then compound 3.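

In this assay, for the compounds shown here, chloro in place of hydrogen on an aromatic carbon gives a 5.9-fold higher number from compound 1 to compound 3 (0.77 log units; beyond the scatter), the first step to lie beyond the scatter, so this position on the aryl ring does respond to substitution. The step of a 9.6-fold higher number from compound 2 to compound 3 (0.98 log units; beyond the scatter) is of similar standing, whereas the change at the carbonyl carbon without the chlorine, a 1.6-fold lower number from compound 1 to compound 2 (0.21 log units; within the scatter), stays within the scatter; among these three compounds, only the steps that add the chlorine go with a shift beyond the scatter. No measurement on hand accounts for this shift.

From the compounds shown here alone, it remains open whether a fluoro, methyl or methoxy group in place of that chlorine gives a step of like size. Going by these compounds, it is equally open whether chloro on the (3-(trifluoromethyl)phenyl)amino group of compound 2 would give the same step.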